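The source may hold more compounds than are shown below. What is called first, only, known or untested is meant among the compounds shown, and "the series" means these compounds.

Of the compounds shown here, two of a shared series have been measured in a functional assay on HCT-116 cells (Homo sapiens) for antiproliferative activity, read by MTT assay, with a stated time of 72 h; a higher number here means a weaker inhibitor, a lower number a stronger inhibitor. Compound 1, `CNC(=O)Nc1nc2ccc(-c3cnc(OC)c(NS(=O)(=O)c4ccc(F)cc4)c3)cc2s1`, gives 870 nM in this assay. Compound 2, `CCN(CC)CCNC(=O)Nc1nc2ccc(-c3cnc(Cl)c(NS(=O)(=O)c4ccc(F)cc4)c3)cc2s1`, gives 920 nM in this assay. Compound 1 holds the lower of the two numbers, but its gap to compound 2 lies within the scatter, so the two readings cannot be told apart.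

The step under consideration leads from compound 1 to compound 3, `COc1ncc(-c2ccc3nc(NC(=O)NCCN4CCN(C)CC4)sc3c2)cc1NS(=O)(=O)c1ccc(F)cc1`. The structural change is (4-methylpiperazin-1-yl)methyl in place of hydrogen on a saturated chain carbon bound to an amide-type nitrogen. The methylcarbamoyl group of compound 1 becomes a (2-(4-methylpiperazin-1-yl)ethyl)carbamoyl group, while the rest of the molecule is kept. Going by the values given here, no measured pair in this set isolates this particular change, so its size in this assay is not known from the data.

Because compound 2, which also bears an extended chain on the urea nitrogen, gives 920 nM and sits within the scatter of compound 1, the step of a 1.1-fold lower number from compound 1 to compound 3 (0.04 log units; within the scatter) is expected to be small and of no clear direction. Compound 3 is estimated to give 800 nM in this assay, with a likely range from 350 nM to 1800 nM.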

Compound 3, half-maximal inhibitory concentration: 540 nM
Estimate against measurement, compound 3: 1.5-fold (0.17 log units) above; the range from low to high includes it.
By their numbers in this assay, from the lowest: compounds 3, 1 and 2 (each within the scatter of the next).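

In this assay, going by these compounds alone, the pair shows a 1.6-fold lower number from compound 1 to compound 3 (0.21 log units; within the scatter) and so gives the first direct reading of (4-methylpiperazin-1-yl)methyl in place of hydrogen on a saturated chain carbon bound to an amide-type nitrogen. The two compounds cannot be told apart, so methyl can give way to 2-(4-methylpiperazin-1-yl)ethyl, which brings in 8 heavy atoms and a six-membered non-aromatic ring, with no difference that this measurement can resolve. No measurement at hand speaks to the reason for this result.

The compounds shown leave open whether the outcome belongs to the 4-methylpiperazine ring or would hold for other groups on the same chain, such as a morpholine ring, a dimethylamino group or a carboxylic acid, or for a longer chain carrying the same ring. They also leave open whether the same change gives a similar step when the rest of the molecule differs, since this single pair reads it only on the core of compound 1.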